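A few compounds are considered here, and "the series" means these few. Any claim that something is new, unique, unknown or untested is made for them only; others in the source may bear on it.

In a functional assay on MCF7 cells (Homo sapiens) for antiproliferative activity, read by MTT assay, with a stated time of 48 h (a higher number here means a weaker inhibitor, a lower number a stronger inhibitor), compound 1 `CC(=O)OC/C1=C/C[C@](C)(CCC=C(C)C)/C=C/[C@@H](OC(=O)C=C(C)C)[C@](C)(O)/C=C/C1=O` gives 4510 nM and compound 2 `COC/C1=C/C[C@](C)(CCC=C(C)C)/C=C/[C@@H](OC(=O)C=C(C)C)[C@](C)(O)/C=C/C1=O` gives 4130 nM, and a 1.1-fold lower number from compound 1 to compound 2 (0.04 log units; within the scatter) stays within the scatter. Compound 3 `CC(C)=CCC[C@]1(C)/C=C/[C@@H](OC(=O)C=C(C)C)[C@](C)(O)/C=C/C(=O)/C(CN(C)C)=C\C1` gives 690 nM, the lowest number of the three, with a 6.5-fold lower number from compound 1 to compound 3 (0.82 log units; beyond the scatter) and a 6.0-fold lower number from compound 2 to compound 3 (0.78 log units; beyond the scatter). Compound 4 `CC(C)=CCC[C@]1(C)/C=C/[C@@H](OC(=O)C=C(C)C)[C@](C)(O)/C=C/C(=O)/C(CN2CCCC2)=C\C1` carries pyrrolidin-1-yl in place of dimethylamino on a saturated chain carbon bound to a double-bonded ring carbon. These measured steps replace acetoxy or methoxy with dimethylamino, and none alters the groups on that nitrogen, so they give no size for this change. No step beyond the scatter is therefore expected, and the expected change is a 1.2-fold lower number from compound 3 to compound 4 (0.06 log units; within the scatter). For compound 4 the estimate is 600 nM, within a range of 250 nM to 1500 nM.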

Compound 4, half-maximal inhibitory concentration: 220 nM
Compound 4: middle estimate off by 2.7-fold (0.44 log units), on the high side; measured number outside the range, below it.
By their numbers in this assay, from the lowest: compound 4; then compound 3; then compounds 2 and 1 (each within the scatter of the next).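

In this assay, the groups on the nitrogen at this saturated chain carbon prove to matter: pyrrolidin-1-yl in place of dimethylamino moves the number beyond the scatter (a 3.1-fold lower number from compound 3 to compound 4 (0.50 log units; beyond the scatter)). Measured against the oxygen-linked groups, pyrrolidin-1-yl gives steps larger than dimethylamino gave, whether from methoxy (a 19-fold lower number from compound 2 to compound 4 (1.27 log units; beyond the scatter)) or from acetoxy (a 21-fold lower number from compound 1 to compound 4 (1.31 log units; beyond the scatter)). No evidence shown accounts for the difference between the two amines. Going by these compounds, it remains open whether a larger ring such as piperidin-1-yl, or morpholin-4-yl, would follow compound 4 in this place, and how a primary amine would compare.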